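The compounds below may be only part of what the source reports. "The series", "measured", "known", "first", "only" and "open" are said of these compounds alone.

Working notes on the series. Compound 1 `CCCCOc1cccc(Nc2nc3nonc3nc2O)c1` carries butoxy on an aromatic carbon; in an assay on mitochondria from L6 cells (Rattus norvegicus) for activation, with a stated time of 90 min (on this read-out higher numbers stand for an effect only at larger amounts of compound and lower numbers for an effect already at smaller amounts), compound 1 gives 2300 nM. Compound 2 `Oc1nc2nonc2nc1Nc1ccccc1` has hydrogen in its place, and in this assay compound 2 gives 66700 nM. Compound 3 `CCc1cccc(Nc2nc3nonc3nc2O)c1` carries ethyl; in this assay compound 3 gives 25200 nM, the second highest of the three numbers, nearest to compound 2 and furthest from compound 1. The relevant steps are a 2.6-fold lower number from compound 2 to compound 3 (0.42 log units; beyond the scatter) and an 11-fold higher number from compound 1 to compound 3 (1.04 log units; beyond the scatter), both beyond the scatter; with a 29-fold higher number from compound 1 to compound 2 (1.46 log units; beyond the scatter) they show the group of more heavy atoms on this carbon paired with the lower number in every measured pair. Compound 4 `CC(C)(C)c1cccc(Nc2nc3nonc3nc2O)c1` is the next member: tert-butyl in place of ethyl on an aromatic carbon. The entering group counts more heavy atoms than the leaving one, in the direction of the step from compound 2 to compound 3, so a modest lowering in this assay is expected rather than none. For compound 4 a value of 9000 nM is estimated, in the range 3000 nM to 25000 nM. The estimate means an expected step of a 2.8-fold lower number from compound 3 to compound 4 (0.45 log units; beyond the scatter).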

Compound 4, half-maximal effective concentration: 2200 nM
Compound 4: middle estimate off by 4.1-fold (0.61 log units), on the high side, and the stated range ends above it.
By their numbers in this assay, from the lowest: compounds 4 and 1 (each within the scatter of the next); then compound 3; then compound 2.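

On this aromatic carbon, meta to a large group, replacing ethyl with tert-butyl gives a much larger step in this assay (an 11-fold lower number from compound 3 to compound 4 (1.06 log units; beyond the scatter)) than replacing hydrogen with ethyl (a 2.6-fold lower number from compound 2 to compound 3 (0.42 log units; beyond the scatter)), so the gain does not rise evenly from one group to the next. Taken from the unsubstituted compound, tert-butyl gives the full step (a 30-fold lower number from compound 2 to compound 4 (1.48 log units; beyond the scatter)). Tert-butyl and butoxy cannot be told apart here (a 1.0-fold lower number from compound 1 to compound 4 (0.02 log units; within the scatter)), so a group without the butoxy oxygen or chain reaches the same level, and compound 1 and compound 4 do not extend the pairing of more heavy atoms with a lower number.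

No measurement shown explains these steps. As far as these compounds go, it remains open whether an amine, a carboxylic acid or a chain longer than butoxy on this carbon would keep the number at this level.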